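Nitro in Place of Hydroxy: A Second Pair to Test

The compounds below may be only part of what the source reports. "The series", "measured", "known", "first", "only" and "open" are said of these compounds alone.

Compound 1 `COc1ccc(C(=O)/C=C\Nc2ccc(-c3nc4cc(OC)c(OC)c(OC)c4s3)cc2C)cc1O`: 15400 nM in a functional assay on MIA PaCa-2 cells (Homo sapiens) for antiproliferative activity, read by sulforhodamine B assay, with a stated time of 48 h; on this read-out higher numbers stand for weaker inhibition and lower numbers for stronger inhibition
Compound 2 `COc1cc(OC)c2sc(-c3ccc(N/C=C\C(=O)c4ccc(OC)c(O)c4)cc3)nc2c1`: 11600 nM in this assay
Compound 3 `COc1ccc(C(=O)/C=C\Nc2ccc(-c3nc4cc(OC)c(OC)c(OC)c4s3)cc2C)cc1[N+](=O)[O-]`: 23400 nM in this assay

Compound 3 arises from compound 1 by nitro in place of hydroxy on an aromatic carbon and this gave a 1.5-fold higher number from compound 1 to compound 3 (0.18 log units; within the scatter). Compound 2 carries a different core from compound 1; the difference between the two cores is not broken down here. Compound 4 `COc1cc(OC)c2sc(-c3ccc(N/C=C\C(=O)c4ccc(OC)c([N+](=O)[O-])c4)cc3)nc2c1` arises from compound 2 by nitro in place of hydroxy on an aromatic carbon, the same change at the same kind of place. Among the compounds with values here, since the one measured instance of this change stayed within the scatter, the step from compound 2 to compound 4 is expected to be small as well, estimated as a 1.5-fold higher number from compound 2 to compound 4 (0.17 log units; within the scatter) in this assay, resting on a 1.5-fold higher number from compound 1 to compound 3 (0.18 log units; within the scatter). Compound 4 is therefore expected to give about 17000 nM in this assay, with a likely range from 8000 nM to 40000 nM.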

Compound 4, half-maximal inhibitory concentration: 2900 nM
Compound 4: the middle estimate sits 5.9-fold (0.77 log units) above what was measured; measured number outside the range, below it.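

On the core of compound 2, nitro in place of hydroxy gave a 4.0-fold lower number from compound 2 to compound 4 (0.60 log units; beyond the scatter) in this assay, so the change did not behave there as it had on the core of compound 1. Set side by side, the two steps differ, and in this series the size of this change cannot simply be carried from one core to the other: the same change on two cores in this assay, a 1.5-fold higher number (0.18 log units; within the scatter) from compound 1 to compound 3 and a 4.0-fold lower number (0.60 log units; beyond the scatter) from compound 2 to compound 4, 6.1-fold (0.78 log units) apart, beyond the scatter of two such steps

The two pairs do not show why the steps part, nor how the change would run on any further core. Still open, on these data alone, is which part of the difference between the two cores decides the outcome, and whether an amine or a carboxylic acid in place of the hydroxy would lower the number as nitro did on the core of compound 2.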